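This account rests on a few compounds, and the source may have more. Where it says the series, first, only, none or still open, it means among the compounds named here.

Measured compounds:
compound 1 `C=CCn1c(SCC(=O)Nc2ccc(C(C)=O)cc2)nnc1-c1ccccc1`: 54%
compound 2 `COc1cc(-c2nnc(SCC(=O)Nc3ccc(/C(C)=N/O)cc3)n2-c2ccccc2)cc(OC)c1OC`: 66%
compound 3 `C=CCn1c(SCC(=O)Nc2ccc(/C(C)=N/O)cc2)nnc1-c1ccccc1`: 73%

In a functional assay on the whole organism (strain albino) for inhibition, with Rattus norvegicus as the target, read by paw edema, with stated times of 30 min and 3 h, at a dose of 0.28 mmol/kg by the oral route (a higher number here means more inhibition at the dose given (going by the name of the read-out), a lower number less inhibition), compound 2 gives 66%, the second highest of the three numbers. It sits within the scatter of compound 3 at 73%, while compound 1 at 54% lies beyond the scatter below it. Compound 4 `COc1ccc(-c2nnc(SCC(=O)Nc3ccc(/C(C)=N/O)cc3)n2-c2ccccc2)cc1` has not been measured; it differs from compound 2 only by 4-methoxyphenyl in place of 3,4,5-trimethoxyphenyl on an aromatic carbon. Among the measured compounds shown here, the single measured step, a number 19 percentage points higher from compound 1 to compound 3 (beyond the scatter), changes a group elsewhere and says nothing about this change, and no measured pair varies the group on this ring carbon. With no guide, the expected step is none beyond the scatter, a number 4 percentage points lower from compound 2 to compound 4 (within the scatter). Compound 4 is therefore estimated at 62%, with a range from 46% to 78%.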

Compound 4, a percentage reported as inhibition, in the whole organism at one dose (the size of the read-out at that dose, not a potency): 57%
Estimate against measurement, compound 4: 5 percentage points above, and the stated range covers the measured number.
By their numbers in this assay, from the lowest: compounds 1, 4, 2 and 3 (each within the scatter of the next, the first and the last beyond it).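

In this assay, 4-methoxyphenyl in place of 3,4,5-trimethoxyphenyl on this aromatic carbon gives a number 9 percentage points lower from compound 2 to compound 4 (within the scatter). Among the compounds shown here, this is the first measured change at this position, and at this dose the two substituted phenyl groups cannot be told apart, so the extra methoxy groups show neither a clear gain nor a clear loss. Nothing measured here explains the result.

Still open, on these data alone, is how this position responds to a group without a phenyl ring, such as an amine or a carboxylic acid.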